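Cyano for Chloro Among Compounds at the Assay Limit

The compounds below may be only part of what the source reports. "The series", "measured", "known", "first", "only" and "open" are said of these compounds alone.

In an ADME assay on MCF-10A cells (Homo sapiens) for inhibition, with a stated time of 48 h (on this read-out higher numbers stand for weaker inhibition and lower numbers for stronger inhibition), compound 1 (`O=C(Nc1ccc(Cl)cc1)N1CCC[C@H]1c1nc(-c2ccccc2)no1`) gives > 50000 nM as a limit of the assay and not a number. Compound 2 (`O=C(Nc1ccc(Cl)cc1)N1CCC[C@H]1c1nc(-c2ccccc2F)no1`) gives > 50000 nM as a limit too. Compound 3 (`O=C(Nc1ccc(Cl)cc1)N1CCC[C@H]1c1nc(-c2cccc(Cl)c2)no1`) gives > 50000 nM as a limit as well, so it stands with the other two (the limit of > 50000 nM in this assay, at which 3 of the 3 values shown sit) and has no number of its own.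

Compound 4 (`N#Cc1cccc(-c2noc([C@@H]3CCCN3C(=O)Nc3ccc(Cl)cc3)n2)c1`) carries cyano in place of chloro on an aromatic carbon, meta to a large group (cyano in place of chloro on an aromatic carbon). The measured steps that bear on this change are all changes to the same aromatic group (a step that the two limits leave unreadable from compound 1 to compound 3; a step that the two limits leave unreadable from compound 1 to compound 2; a step that the two limits leave unreadable from compound 2 to compound 3). Going by the values given here, none of them has a readable size, so they offer no measured step to carry over and no direction to follow. No change beyond the usual scatter is expected, and the estimated step is a number no higher from compound 3 to compound 4 (the limit leaves the size open) in this assay on that basis. For compound 4 the estimate is 50000 nM with an expected range of 25000 nM to 100000 nM and a reading at the limit as the likeliest result.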

Compound 4, half-maximal inhibitory concentration: > 50000 nM
Compound 4: a limit, no number; the forecaster's own chance of this, stated with the estimate: 85%; the middle value lies on the limit itself.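

Compound 4 gives a limit of the assay and not a number, so no step between it and compound 1, compound 2 or compound 3 can be read in this assay: the limit of > 50000 nM in this assay, at which 4 of the 4 values shown sit.

The compounds shown leave open whether these aromatic groups differ at all in inhibition, with no number for any of the four.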